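Isopropylcarbonyl on the hydroxy oxygen of compound 2

This account rests on a few compounds, and the source may have more. Where it says the series, first, only, none or still open, it means among the compounds named here.

Two compounds carry numbers in a functional assay on A549 cells (Homo sapiens) for cytotoxicity, with a stated time of 48 h; a lower number here means a stronger inhibitor, a higher number a weaker inhibitor. Compound 1 `Cc1ccc2c(=O)cc(/C=C/[S+](C)[O-])oc2c1` gives 2000 nM there. Compound 2 `C[S+]([O-])/C=C/c1cc(=O)c2cc(O)ccc2o1` gives 10500 nM in this assay, the higher of the two numbers, and the gap to compound 1 lies beyond the scatter. Within the data shown here, compound 1 and compound 2 differ in more than one place, so no single counted step links them.

Compound 3 `CC(C)C(=O)Oc1ccc2oc(/C=C/[S+](C)[O-])cc(=O)c2c1` is the next compound. It differs from compound 2 by isopropylcarbonyl in place of hydrogen on an oxygen on an aromatic ring. Among the measured compounds shown here, no measured pair shows this change, so the expectation rests on the two numbers above alone. Since compound 2 holds the higher number of the pair, a move toward the lower number of compound 1, 2000 nM, looks the more likely direction, and a step of moderate size is expected. The step of a 2.3-fold lower number from compound 2 to compound 3 (0.37 log units; beyond the scatter) is expected to fall toward a lower number, near the edge of the scatter. Compound 3 is expected to give 4500 nM, with a range from 1500 nM to 14000 nM.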

Compound 3, half-maximal inhibitory concentration: 2400 nM
The estimate for compound 3 lay 1.9-fold (0.27 log units) above the measured number; the range from low to high includes it.
By their numbers in this assay, from the lowest: compounds 1 and 3 (each within the scatter of the next); then compound 2.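

In this assay, among these compounds, replacing the hydrogen on the hydroxy oxygen of compound 2 with isopropylcarbonyl gives the first counted step at this position (a 4.4-fold lower number from compound 2 to compound 3 (0.64 log units; beyond the scatter)), a modest change beyond the scatter. The free hydroxy is therefore not required for the measured cytotoxicity, and this oxygen tolerates a substituent of 5 heavy atoms with 0 hydrogen-bond donors without any loss in the read-out. Nothing measured here bears on the origin of this step.

A single substituent cannot show whether the step is specific to isopropylcarbonyl or would also appear with a smaller acetyl group, a longer acyl chain or a methyl ether on the same oxygen. From the compounds shown here alone, whether the step carries over to cell lines other than the one tested here also remains open.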